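Swapping cyano for methylsulfanyl on compound 1

This account rests on a few compounds, and the source may have more. Where it says the series, first, only, none or still open, it means among the compounds named here.

Measured so far in a physicochemical assay for solubility, read by nephelometry, at pH 7.4 (on this read-out higher numbers stand for higher solubility and lower numbers for lower solubility), as follows:
- compound 1 `COc1cccc(NC(=O)c2nnn(Cc3ccc(C#N)cc3)c2N)c1` gives 216000 nM
- compound 2 `COc1cccc(NC(=O)c2nnn(C(C)c3ccc(C(C)(C)C)cc3)c2N)c1` gives 20000 nM
- compound 3 `COc1cccc(NC(=O)c2nnn(CC3CCN(C(=O)OC(C)(C)C)CC3)c2N)c1` gives 39000 nM

Compound 1 stands highest of the three, and compound 3 and compound 2 both lie lower by margins beyond the scatter. Compound 4 `COc1cccc(NC(=O)c2nnn(Cc3ccc(SC)cc3)c2N)c1` keeps the core of compound 1 and changes one group, 4-cyanophenyl to 4-(methylsulfanyl)phenyl (methylsulfanyl in place of cyano on an aromatic carbon). Among the compounds with values here, no measured pair shows this change, so the guide is thin. Compound 1 sits at the top of this small set, so a drop in this assay towards the other two compounds seems likeliest. The estimated step (a 4.8-fold lower number from compound 1 to compound 4 (0.68 log units; beyond the scatter)) is a drop expected to lie beyond the scatter. For compound 4 the expected value is 45000 nM (estimated range 15000 nM to 120000 nM).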

Compound 4, solubility: < 12000 nM
Compound 4: only a limit was reported (the forecaster's own chance of this, stated with the estimate: 5%); at least 3.7-fold (0.57 log units) between middle value and limit.
By their numbers in this assay, from the lowest: compounds 2 and 3 (each within the scatter of the next); then compound 1. At a limit, below all of these: compound 4.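

In this assay, methylsulfanyl in place of cyano on an aromatic carbon, para to a large group, gives an at least 18-fold lower number from compound 1 to compound 4 (1.25 log units; beyond the scatter), the first single-place change seen here, and it shows that this position responds strongly. The two groups have the same counts of heavy atoms, hydrogen-bond donors and hydrogen-bond acceptors, so those counts do not account for the step. The result for compound 4 is a limit, not a number: the limit of < 12000 nM in this assay, at which 1 of the 4 values shown sits.

The compounds shown leave open how an amine or a carboxylic acid at this position would compare with cyano. They also leave open whether the same swap on a different core would give a similar step.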